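Changing the Carbamate on an Amidine: Oral Bioavailability

The source may report more compounds than this note shows. Statements on the series, on what has been measured and on what is new or still open speak of the compounds shown alone.

Measured compounds:
Compound 1 `N/C(=N/O)c1ccc2[nH]c(-c3cccc(-c4ccccc4O)c3O)cc2c1`: 15%
Compound 2 `CC(C)OC(=O)NC(=N)c1ccc2[nH]c(-c3cccc(-c4ccccc4O)c3O)cc2c1`: 23%

In an in vivo ADME assay on the whole organism (strain Sprague-Dawley) for pharmacokinetics, with Rattus norvegicus as the target (on this read-out higher numbers stand for higher oral bioavailability and lower numbers for lower oral bioavailability), compound 2 gives 23%, and compound 1 gives 15%. Going by the values given here, the only measured step, a number 8 percentage points higher from compound 1 to compound 2 (within the scatter), lies within the scatter, so the two compounds cannot be ranked against each other on this assay. Compound 3 `N/C(=N/C(=O)OCC(Cl)(Cl)Cl)c1ccc2[nH]c(-c3cccc(-c4ccccc4O)c3O)cc2c1` is reached from compound 2 by a group of 11 heavy atoms (4 carbon, 2 nitrogen, 2 oxygen, 3 chlorine; no ring) in place of a group of 9 heavy atoms (5 carbon, 2 nitrogen, 2 oxygen; no ring), on an aromatic carbon; the carbamate on the amidine is kept, and only the alcohol part of it changes. Among the compounds with values here, the one step that bears on this region, a number 8 percentage points higher from compound 1 to compound 2 (within the scatter), exchanged the whole carbamate for a plain amidoxime and still stayed within the scatter. On that basis the change to compound 3 is expected to give a number 1 percentage points lower from compound 2 to compound 3 (within the scatter), no step beyond the scatter in either direction. Compound 3 is therefore estimated at 22%, with a range from 9% to 38%.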

Compound 3, oral bioavailability: 14%
Beside the measured number, compound 3's estimate is 8 percentage points above it; low and high end bracket the measured number.
By their numbers in this assay, from the lowest: compounds 3, 1 and 2 (each within the scatter of the next).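

In this assay, the new steps are a number 9 percentage points lower from compound 2 to compound 3 (within the scatter) and a number 1 percentage points lower from compound 1 to compound 3 (within the scatter). So neither changing the alcohol part of the carbamate nor placing (2,2,2-trichloroethoxy)carbonyl in place of hydroxy on a double-bonded nitrogen gives a step beyond the scatter, and compound 1, compound 2 and compound 3 cannot be ranked against one another. Nothing available explains why these numbers fall where they do.

The compounds shown leave open whether an acetyl group on that nitrogen, or a longer alkyl chain in the alcohol part of the carbamate, would separate from these three in this assay. They also leave open how the plain amidine, with only hydrogen on that nitrogen, would compare.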